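A few compounds are considered here, and "the series" means these few. Any claim that something is new, unique, unknown or untested is made for them only; others in the source may bear on it.

Measured so far in a functional assay on MCF7 cells (Homo sapiens) for cytotoxicity, read by sulforhodamine B assay, with a stated time of 48 h; a lower number here means a stronger inhibitor, a higher number a weaker inhibitor:
- compound 1, `CC1=C(/C=C/C(=O)/C=C/c2ccc(F)cc2)C(C)(C)CCC1`: 6200 nM
- compound 2, `CC1=C(/C=C/C(=O)/C=C/c2ccccc2Cl)C(C)(C)CCC1`: 54600 nM
- compound 3, `CC1=C(/C=C/C(=O)/C=C/c2ccccc2[N+](=O)[O-])C(C)(C)CCC1`: 10100 nM

Compound 3 stands second highest of the three numbers in this assay. Its nearest neighbour is compound 1, and the gap between the two lies within the scatter; its furthest is compound 2, with a gap beyond the scatter.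

The next compound is compound 4, `CC1=C(/C=C/C(=O)/C=C/c2ccccc2F)C(C)(C)CCC1`. Its difference from compound 3 is fluoro in place of nitro on an aromatic carbon.

Among the measured compounds shown here, two measured steps bear on this change. The step of a 5.4-fold lower number from compound 2 to compound 3 (0.73 log units; beyond the scatter) shows that nitro in place of chloro on the aromatic carbon moved the number down beyond the scatter; reversing that direction, halogen in place of nitro, would point to a higher number. The step of an 8.8-fold higher number from compound 1 to compound 2 (0.94 log units; beyond the scatter) shows that a halogen on the same aromatic carbon gave a clearly higher number than the halogen of compound 1, though that step also changes the halogen itself, so it is only a partial guide.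

Taken together, a modest rise beyond the scatter is expected for compound 4 relative to compound 3, the step being estimated as a 1.8-fold higher number from compound 3 to compound 4 (0.25 log units; within the scatter). In this assay compound 4 is therefore expected to give about 18000 nM, with a plausible range from 6000 nM to 50000 nM.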

Compound 4, half-maximal inhibitory concentration: 11000 nM
The estimate for compound 4 lay 1.6-fold (0.21 log units) above the measured number; measured number inside the range.
By their numbers in this assay, from the lowest: compounds 1, 3 and 4 (each within the scatter of the next); then compound 2.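

In this assay, the aromatic carbon that carries nitro in compound 3 takes fluoro with no change beyond the scatter: a 1.1-fold higher number from compound 3 to compound 4 (0.04 log units; within the scatter). At that same carbon chloro stands apart from fluoro as well as from nitro, with a 5.0-fold lower number from compound 2 to compound 4 (0.70 log units; beyond the scatter), so the high number of compound 2 goes with chloro itself and not with any group at this carbon. Shifting the halogen, 2-fluorophenyl in place of 4-fluorophenyl, gives a 1.8-fold higher number from compound 1 to compound 4 (0.25 log units; within the scatter), so the place of fluoro on the ring makes no difference beyond the scatter, and the earlier rise on reaching compound 2 follows the change to chloro rather than the change of place.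

Nothing measured here accounts for the separate standing of chloro. Still open, as far as these compounds go, is whether bromo at this carbon follows chloro or joins fluoro and nitro, and whether an amine or a methoxy group there stays level with them, which would show if chloro alone stands apart.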